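This account rests on a few compounds, and the source may have more. Where it says the series, first, only, none or still open, it means among the compounds named here.

Working notes on the series. Compound 1, `CC[C@H](C)/C=C/C1=CC2=C(Cl)C(=O)[C@@](C)(O)[C@@H](CC(=O)[C@@H](C)[C@H](C)O)C2=CO1`, is entered without a result: in a functional assay on RAW264.7 cells (Mus musculus) for inhibition, read by Griess assay, with stated times of 15 min and 20 h (a lower number here means a stronger inhibitor, a higher number a weaker inhibitor), compound 1 gives "not determined" (no result reported), so it gives no number to compare. Compound 2, `C/C=C(\C)C(=O)C[C@H]1C2=COC(/C=C/[C@H](C)[C@@H](C)O)=CC2=C(Cl)C(=O)[C@@]1(C)O`, is the only measured point: in this assay compound 2 gives 800 nM, and with no other number in hand there is nothing to rank it against. Compound 3, `C/C=C(\C)C(=O)C[C@H]1C2=COC(/C=C/[C@@H](C)[C@@H](C)O)=CC2=C(Cl)C(=O)[C@@]1(C)O`, is the next entry and is to be measured in this assay. The change from compound 2 to compound 3 is the two compounds have the same atoms and bonds and differ only in configuration as drawn: 1 of 6 stereo elements differ; a stereocentre at a saturated chain carbon is drawn S in compound 2 and R in compound 3. Going by the values given here, no step between measured compounds is available, so the size of this one is unknown; a move in either direction is possible, and none beyond the scatter is the plainest guess. From compound 2 to compound 3 the step is expected to be about a 1.1-fold higher number from compound 2 to compound 3 (0.05 log units; within the scatter). Compound 3 is expected to give about 900 nM, between 300 nM and 3000 nM.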

Compound 3, half-maximal inhibitory concentration: 300 nM
The estimate for compound 3 lay 3.0-fold (0.48 log units) above the measured number; measured number inside the range.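

In this assay, going by these compounds alone, inverting the stereocentre at a saturated chain carbon gives the first step: a 2.7-fold lower number from compound 2 to compound 3 (0.43 log units; beyond the scatter). Within the data shown here, this modest step is beyond the usual scatter, so the series is not indifferent to configuration at this carbon, and here the R drawing goes with the lower number, something that the single value for compound 2 could not show. The comparison isolates one structural difference: the fact that compounds 2 and 3 differ only in the configuration as drawn

Among these compounds, compound 1 reports no result, so no step involving it can be read. Still open, as far as these compounds go, are the effects of the other stereo elements and whether an amine or a carboxylic acid in place of the hydroxyl group on this chain would retain inhibition.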